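The source may hold more compounds than are shown below. What is called first, only, known or untested is meant among the compounds shown, and "the series" means these compounds.

In a functional assay on TK-10 cells (Homo sapiens) for antiproliferative activity, with a stated time of 48 h (a lower number here means a stronger inhibitor of growth, a higher number a weaker inhibitor of growth), compound 1 `Cc1cc(O)c(C2=NN(c3ccc(S(N)(=O)=O)cc3)C(c3ccccc3O)C2)cc1Cl` gives 3300 nM. Compound 2 `Cc1cc(O)c(C2=NN(c3ccc(S(N)(=O)=O)cc3)C(c3ccccc3Cl)C2)cc1Cl` gives in this assay 2640 nM. For the measured compounds named here, the only measured step, a 1.3-fold lower number from compound 1 to compound 2 (0.10 log units; within the scatter), lies within the scatter, so the two numbers measured so far cannot be told apart, and compound 2 stands level with compound 1 rather than apart from it.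

Compound 3 `Cc1cc(O)c(C2=NN(c3ccc(S(N)(=O)=O)cc3)C(/C=C/c3ccccc3)C2)cc1Cl` has not yet been measured in this assay. It differs from compound 2 by 2-phenylethenyl in place of 2-chlorophenyl on a saturated ring carbon. Going by the values given here, no measured step bears directly on this change: the one step known concerns a different group, and it stayed within the scatter. With nothing in the data pointing in either direction, compound 3 is estimated to give about 3000 nM, with a range from 900 nM to 10000 nM. This estimate means an expected step of a 1.1-fold higher number from compound 2 to compound 3 (0.06 log units; within the scatter), none beyond the scatter.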

Compound 3, concentration for 50% growth inhibition: 14800 nM
The estimate for compound 3 lay 4.9-fold (0.69 log units) below the measured number, outside the stated range (above it).
By their numbers in this assay, from the lowest: compounds 2 and 1 (each within the scatter of the next); then compound 3.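

At the saturated ring carbon next to the ring nitrogen, the change between 2-hydroxyphenyl and 2-chlorophenyl had left the numbers level, but 2-phenylethenyl in this assay brings a 5.6-fold higher number from compound 2 to compound 3 (0.75 log units; beyond the scatter) and a 4.5-fold higher number from compound 1 to compound 3 (0.65 log units; beyond the scatter). This position therefore does respond to the group it carries: among these three compounds, the two with a substituted phenyl group stand together, and the one with 2-phenylethenyl is the weaker inhibitor of growth. No evidence at hand accounts for this step.

The compounds shown leave open whether the step follows the double bond or the two-carbon link itself, a question a 2-phenylethyl group would address. They also leave open how a group without an aromatic ring, such as a short alkyl chain or an amine, would stand at this carbon.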